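Amide ring substituent change in the carbinol series

The source may report more compounds than this note shows. Statements on the series, on what has been measured and on what is new or still open speak of the compounds shown alone.

Compound 1 `O=C(N1CCCCC1)n1ncc(C(O)(c2ccccc2)c2ccccc2)n1` is reported in an assay on isolated protein for inhibition of Acyl-protein thioesterase 1 (Homo sapiens) (a lower number here means a stronger inhibitor, a higher number a weaker inhibitor), only as a limit, < 30 nM. Among the compounds with values here, compound 2 `CC(C)(C)C1CCN(C(=O)n2ncc(C(O)(c3ccccc3)c3ccccc3)n2)CC1` gives 17 nM in this assay, the only plain number in the set. The other value, that of compound 1, is the limit (the limit of < 30 nM in this assay, at which 1 of the 2 values shown sits). The step from compound 1 to compound 2, a step that the limit leaves unreadable from compound 1 to compound 2, is therefore not readable in size.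

Compound 3 `CCC1CCCCN1C(=O)n1ncc(C(O)(c2ccccc2)c2ccccc2)n1` differs from compound 2 by 2-ethylpiperidin-1-yl in place of 4-(tert-butyl)piperidin-1-yl on a carbonyl carbon. Within the data shown here, no measured step touches the same change; the single step available, a step that the limit leaves unreadable from compound 1 to compound 2, is hidden by the limit and gives no scale for moving a tert-butyl group off a saturated ring carbon and placing an ethyl group on another ring carbon. With the two values shown sitting close together, the expectation for compound 3 is no step beyond the scatter, in either direction, and a 1.3-fold higher number from compound 2 to compound 3 (0.11 log units; within the scatter) is the estimated size. Compound 3 is therefore expected to give about 22 nM in this assay, within 6 nM to 80 nM.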

Compound 3, half-maximal inhibitory concentration: > 10000 nM
Compound 3 was reported as a limit; the forecaster's own chance of this, stated with the estimate: 25%; middle value at least 450-fold (2.65 log units) from the limit.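

In this assay, this position on a carbonyl carbon does not accept every substituted piperidine: 2-ethylpiperidin-1-yl in place of 4-(tert-butyl)piperidin-1-yl gives an at least 580-fold higher number from compound 2 to compound 3 (2.76 log units; beyond the scatter), and ethyl in place of hydrogen on a saturated ring carbon gives an at least 330-fold higher number from compound 1 to compound 3 (2.52 log units; beyond the scatter). The earlier pair did not show this, since the 4-(tert-butyl)piperidin-1-yl group of compound 2 still gives 17 nM, so a substituent on the piperidine does not in itself remove inhibition, and the smaller 2-ethylpiperidin-1-yl group is enough to produce a large loss. Compound 3 gives > 10000 nM, which is a limit and not a number, and nothing shown here gives a cause for the loss.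

On these data alone, the steps from compound 1 to compound 2 cannot be read, so what the tert-butyl group itself adds or costs remains open. Also open, as far as these compounds go, is whether the loss follows the ethyl group or the place it occupies, which a 4-ethylpiperidin-1-yl or a 2-methylpiperidin-1-yl group on the same carbonyl carbon would help to separate.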